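Swapping cyano for hydrogen on a cytotoxicity probe

The source may hold more compounds than are shown below. What is called first, only, known or untested is meant among the compounds shown, and "the series" means these compounds.

Measured so far:
compound 1, `Cc1nnc(SCC(=O)N/N=c2/scc(-c3ccccc3)n2-c2ccccc2)s1`, 72.5%
compound 2, `Cn1cnnc1SCC(=O)N/N=c1/scc(-c2ccc(C#N)cc2)n1-c1ccccc1`, 62.6%

Both compounds were tested in a functional assay on C6 cells (Rattus norvegicus) for cytotoxicity, read by MTT assay, with a stated time of 24 h, tested at 12 ug/mL; a higher number here means a weaker effect of the compound at the concentration tested, a lower number a stronger effect. Compound 2, `Cn1cnnc1SCC(=O)N/N=c1/scc(-c2ccc(C#N)cc2)n1-c1ccccc1`, gives 62.6% and is the lower of the two numbers seen so far, but its nearest neighbour, compound 1, sits only a little higher, and the gap between the two lies within the scatter of this kind of measurement. Compound 1 and compound 2 differ in two places at once, so their two values show no clean effect of any single change.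

The next compound, compound 3, `Cn1cnnc1SCC(=O)N/N=c1/scc(-c2ccccc2)n1-c1ccccc1`, differs from compound 2 in one place only: hydrogen in place of cyano on an aromatic carbon. The cyano group sits on a six-membered aromatic ring of carbon only, and its removal leaves the rest of the molecule untouched. For the measured compounds named here, no pair of measured compounds isolates this change, so there is nothing to calibrate a step against. The safest expectation is a step in this assay that stays within the scatter, if anything drifting slightly upward, toward the number for compound 1.

Compound 3 is therefore expected at 68%, with a range from 54% to 82%, which corresponds to an expected step of a number 5.4 percentage points higher from compound 2 to compound 3 (within the scatter).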

Compound 3, a percentage reported as activity, at one concentration (the size of the read-out at that concentration, not a potency): 79.6%
For compound 3 the middle estimate is 11.6 percentage points below the measured one; measured number inside the range.
By their numbers in this assay, from the lowest: compounds 2, 1 and 3 (each within the scatter of the next, the first and the last beyond it).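

In this assay, for the compounds shown here, hydrogen in place of cyano on the six-membered aromatic ring of carbon only gives a number 17 percentage points higher from compound 2 to compound 3 (beyond the scatter) and is the first single change here that can be read on its own: at the concentration tested, the effect is stronger with the cyano group present than with hydrogen. The other single change, 4-methyl-4H-1,2,4-triazol-3-yl in place of 5-methyl-1,3,4-thiadiazol-2-yl on a sulfur, gives a number 7.1 percentage points higher from compound 1 to compound 3 (within the scatter) and so shows no difference that can be told from ordinary scatter between these two groups when the aromatic ring carries only hydrogen. No measurement at hand accounts for the step seen with the cyano group.

On these data alone, it remains open whether other groups at the same place, such as a methoxy group, a chlorine atom or a carboxylic acid, would match the cyano group, or whether any effect depends on this particular group. Also unresolved is whether the cyano group would have a similar effect alongside the 5-methyl-1,3,4-thiadiazol-2-yl group, and a reading at one concentration does not give a potency.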